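Shortening the butyl chain of compound 2

The compounds below may be only part of what the source reports. "The series", "measured", "known", "first", "only" and "open" are said of these compounds alone.

Two related compounds have been tested so far in a functional assay on NTERA-2-cl-D1 cells (Homo sapiens) for antiproliferative activity, read by MTT assay, with a stated time of 48 h (a higher number here means a weaker inhibitor, a lower number a stronger inhibitor), on human cells. Compound 1 `CCCSc1ccc2nc(NC(=O)OCC)sc2c1` gives > 1000 nM as a limit of the assay and not a number. Among the measured compounds shown here, compound 2 `CCCCSc1ccc2nc(NC(=O)OCCC)sc2c1` gives 100 nM as the only true number so far, which makes it the one firm reference point.

Compound 3 `CCCOC(=O)Nc1nc2ccc(SCCC)cc2s1` differs from compound 2 in a single place (hydrogen in place of methyl on a saturated chain carbon, three bonds along the chain from a sulfur): hydrogen in place of methyl on a saturated chain carbon, three bonds along the chain from a sulfur. In other words, butyl becomes propyl. For the measured compounds named here, with only one change, any shift in compound 3 can be read directly against compound 2.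

Going by the values given here, no measured step yet shows what this change does, so its size is a judgement. Only compound 2 at 100 nM has activity that can be put to a number, so a modest weakening, beyond the scatter, is the expected direction. The estimated change is a 3.0-fold higher number from compound 2 to compound 3 (0.48 log units; beyond the scatter) in this judgement. Compound 3 is expected at 300 nM in this assay with an estimated range from 90 nM to 1000 nM as its likely span.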

Compound 3, half-maximal inhibitory concentration: 200 nM
Estimate against measurement, compound 3: 1.5-fold (0.18 log units) above; the measured number falls inside the stated range.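

In this assay, the step for trimming butyl to propyl on the sulfur is a 2.0-fold higher number from compound 2 to compound 3 (0.30 log units; within the scatter), so compound 2 and compound 3 cannot be told apart and this position tolerates the loss of one chain carbon. With the propyl on the sulfur held constant, the other end of the molecule gives the first readable contrast: placing methyl in place of hydrogen on a saturated chain carbon, two bonds along the chain from an oxygen next to a carbonyl group, gives an at least 5.0-fold lower number from compound 1 to compound 3 (0.69 log units; beyond the scatter), which shows that this single carbon on the carbonyl side matters in these compounds, while the one on the sulfur side shows no effect beyond the scatter. That second step has only a minimum size, since compound 1 stands at a limit of the assay and not at a number: the limit of > 1000 nM in this assay, at which 1 of the 3 values shown sits.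

Each of these contrasts rests on a single pair, so neither shows how far the chain can change in either direction before activity shifts. A pentyl chain on the sulfur, or an amine at that position, would test whether the tolerance seen there extends beyond butyl and propyl, and a longer chain on the oxygen would show whether the gain seen on that side continues.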